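A few compounds are considered here, and "the series" means these few. Any claim that something is new, unique, unknown or untested is made for them only; others in the source may bear on it.

Measured so far in a functional assay on DU-145 cells (Homo sapiens) for inhibition, read by trypan blue exclusion, with a stated time of 96 h; on this read-out lower numbers stand for stronger inhibition of growth and higher numbers for weaker inhibition of growth:

Compound 1 `Cc1ccsc1/C=C(/SCc1ccc(Cl)c(Cl)c1)C(=O)c1ccc(Cl)cc1` gives 50000 nM
Compound 2 `COc1cc(/C=C(/Sc2ccc(Br)cc2)C(=O)c2ccc(Br)cc2)ccc1F` gives 10000 nM
Compound 3 `O=C(O)c1cc(/C=C(/Sc2ccc(Br)cc2)C(=O)c2c(F)c(F)c(F)c(F)c2F)ccc1O` gives 25000 nM

Compound 2 holds the lowest number of the three (at 10000 nM) and stands beyond the scatter from both compound 3 and compound 1. Compound 4 `O=C(/C(=C\c1ccc(I)cc1)Sc1ccc(Br)cc1)c1ccc(Br)cc1` has not yet been measured and differs from compound 2 in one place (4-iodophenyl in place of 4-fluoro-3-methoxyphenyl on a double-bonded chain carbon bound to a double-bonded chain carbon) only. Among the measured compounds shown here, no measured pair shows what this exchange does, so no step beyond the scatter is expected in this assay for it. The expected change (a 1.2-fold higher number from compound 2 to compound 4 (0.08 log units; within the scatter)) is estimated to stay within the scatter. Compound 4 is expected at 12000 nM within a range from 3500 nM to 40000 nM as estimated here.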

Compound 4, concentration for 50% growth inhibition: 1000 nM
Compound 4: the middle estimate sits 12-fold (1.08 log units) above what was measured, outside the stated range (below it).
By their numbers in this assay, from the lowest: compound 4; then compound 2; then compounds 3 and 1 (each within the scatter of the next).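

In this assay, the exchange of one substituted phenyl group for another gives a 10-fold lower number from compound 2 to compound 4 (1.00 log units; beyond the scatter), the first measured sign that a single exchange at this position can move the number beyond the scatter. The exchange removes the methoxy group and the fluorine and brings in iodine, so the step cannot be assigned to any one of these atoms or groups. No measurement shown here explains the step.

The compounds shown leave open whether the iodine itself matters, and how a phenyl ring carrying an amine or a nitrile in its place would read.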